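This account rests on a few compounds, and the source may have more. Where it says the series, first, only, none or still open, it means among the compounds named here.

Measured compounds:
Compound 1, `Cn1nnc2c(C(N)=O)cccc2c1=O`: in a functional assay on TLX-5 cells (Mus musculus) for cytotoxicity (on this read-out higher numbers stand for weaker inhibition and lower numbers for stronger inhibition), compound 1 gives > 500000 nM, which is a limit of the assay.
Compound 2, `CCn1nnc2cc(C(N)=O)ccc2c1=O`: in this assay compound 2 gives 108000 nM.
Compound 3, `CCn1nnc2c(C(N)=O)cccc2c1=O`: in this assay compound 3 gives 325000 nM.

Among the two numbers, compound 3 stands highest, and compound 2 sits below it beyond the scatter. Compound 4, `NC(=O)c1cccc2c(=O)n(-c3ccccc3)nnc12`, differs from compound 3 by phenyl in place of ethyl on an aromatic nitrogen. Within the data shown here, the only measured step at this aromatic nitrogen, an at least 1.5-fold lower number from compound 1 to compound 3 (0.18 log units; that floor lies within the scatter), is bounded by a limit and shows no change beyond the scatter, so compound 3 gives no footing for a large move in this assay on going to phenyl. The step from compound 3 to compound 4 is therefore expected to be small, a 1.3-fold lower number from compound 3 to compound 4 (0.11 log units; within the scatter), with the direction uncertain. Compound 4 is estimated at 250000 nM, within 80000 nM to 800000 nM.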

Compound 4, half-maximal inhibitory concentration: > 500000 nM
Compound 4 gave a limit, no number; the forecaster's own chance of this, stated with the estimate: 30%; at least 2.0-fold (0.30 log units) between middle value and limit.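

At this aromatic nitrogen, phenyl in place of ethyl gives an at least 1.5-fold higher number from compound 3 to compound 4 (0.18 log units; that floor lies within the scatter) in this assay, so the larger ring brings no readable gain over ethyl, though the printed floor does not establish a rise. Compound 1 and compound 4 both stand at a limit, so the step between them cannot be read, and the true size of the step from ethyl to phenyl stays hidden: the limit of > 500000 nM in this assay, at which 2 of the 4 values shown sit.

On these data alone, whether a propyl chain or a benzyl group on this nitrogen would give a readable number remains open. So does whether phenyl would behave alike on the core of compound 2.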